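Pyrrolidin-1-yl for propanoyl in a low-scoring compound

The compounds below may be only part of what the source reports. "The series", "measured", "known", "first", "only" and "open" are said of these compounds alone.

In an ADME assay on microsomes from liver (Rattus norvegicus, strain Sprague-Dawley) for metabolic stability, read by LC-MS, with a stated time of 15 min, tested at 20 uM (a lower number here means that less of the compound is left, a higher number that more of the compound is left), compound 1 (`COc1cccc(CNC(=O)c2c(C)nc3cc(C)ccn23)c1`) gives 94% and compound 2 (`COc1ccccc1CNC(=O)c1c(C)nc2cc(C)ccn12`) gives 41.6% as its reading. Compound 3 (`CCC(=O)c1ccccc1OC(=O)c1coc(-c2ccccc2)n1`) is built differently from both, and its 8.7% is the lowest of the three numbers. Even the nearer of the other two, compound 2, lies beyond the usual scatter from it, and compound 1 lies further off still.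

Compound 4 (`O=C(Oc1ccccc1N1CCCC1)c1coc(-c2ccccc2)n1`) has not yet been measured. It keeps everything in compound 3 except one group, with pyrrolidin-1-yl in place of propanoyl on an aromatic carbon. For the measured compounds named here, no two measured compounds differ in a single place, so the data hold no direct guide to what this swap does. The best available anchor is compound 3 with its 8.7% reading, since the rest of the structure stays the same. In this assay only a small rise is expected, and the estimated a number 3.3 percentage points higher from compound 3 to compound 4 (within the scatter) is not expected to go beyond the scatter. Compound 4 is therefore expected to stay at the low end of the numbers seen so far. Compound 4 is estimated at 12% (expected range 2% to 35%).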

Compound 4, percent of the compound remaining: 11.2%
Compound 4: middle estimate off by 0.8 percentage points, on the high side, within the range that was stated.
By their numbers in this assay, from the lowest: compounds 3 and 4 (each within the scatter of the next); then compound 2; then compound 1.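

In this assay, for the compounds shown here, the exchange of propanoyl for pyrrolidin-1-yl gives the first direct reading of a single change at this place, on an aromatic carbon ortho to a large group (a number 2.5 percentage points higher from compound 3 to compound 4 (within the scatter)). The two groups differ clearly on paper: the one that leaves is an open chain with a double bond outside the aromatic rings, and the one that enters is a five-membered non-aromatic ring holding a nitrogen, yet this difference does not carry the reading beyond the scatter. The data offer no measured explanation for this result.

This single pair cannot show whether the place is insensitive to change in general or whether these two groups merely happen to give similar readings. A carboxylic acid, a morpholine ring or a longer chain at this place could test that, and a change elsewhere in the shared structure could show whether any other part of compound 4 has a larger bearing on the percent remaining.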